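The source may hold more compounds than are shown below. What is called first, only, known or untested is meant among the compounds shown, and "the series" means these compounds.

The study concerns a series built on one shared core, varied at the nitrogen on an aromatic ring that carries the aniline-type substituent. Compound 1 `COc1ncc(-c2ccc3ncnc(Nc4ccc(OCCO)cc4)c3c2)cc1NS(=O)(=O)c1ccc(F)cc1F` gives 1650 nM in a functional assay on MCF7 cells (Homo sapiens) for antiproliferative activity, read by sulforhodamine B assay, with a stated time of 72 h; on this read-out higher numbers stand for weaker inhibition and lower numbers for stronger inhibition. Within the data shown here, compound 2 `COc1ncc(-c2ccc3ncnc(Nc4ccc(OCCO)nc4)c3c2)cc1NS(=O)(=O)c1ccc(F)cc1F` gives 4300 nM in this assay, and among the two numbers measured it stands highest, with compound 1 as its only neighbour at a lower number. Among the measured compounds shown here, the step between them, a 2.6-fold higher number from compound 1 to compound 2 (0.42 log units; beyond the scatter), is the one measured change that bears on what comes next.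

Compound 3 `COc1cc(Nc2ncnc3ccc(-c4cnc(OC)c(NS(=O)(=O)c5ccc(F)cc5F)c4)cc23)ccc1OCCO` has not yet been measured. Relative to compound 2 it carries 4-(2-hydroxyethoxy)-3-methoxyphenyl in place of 6-(2-hydroxyethoxy)pyridin-3-yl on a nitrogen on an aromatic ring. This change undoes the aromatic-ring swap that defined the step from compound 1 to compound 2, while adding a methoxy group to the incoming phenyl ring. Because the step of a 2.6-fold higher number from compound 1 to compound 2 (0.42 log units; beyond the scatter) raised the number, the return to a carbon-only ring is expected to lower it again by a similar margin, the extra methoxy group being an untested variable. Compound 3 is therefore estimated to give 1800 nM in this assay, within a range of 700 nM to 4500 nM, corresponding to an expected step of a 2.4-fold lower number from compound 2 to compound 3 (0.38 log units; beyond the scatter).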

Compound 3, half-maximal inhibitory concentration: 2260 nM
Compound 3: middle estimate off by 1.3-fold (0.10 log units), on the low side, within the range that was stated.
By their numbers in this assay, from the lowest: compounds 1, 3 and 2 (each within the scatter of the next, the first and the last beyond it).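

In this assay, methoxy in place of hydrogen on the 4-(2-hydroxyethoxy)phenyl group comes with a 1.4-fold higher number from compound 1 to compound 3 (0.14 log units; within the scatter), so this addition, on the group carried by the nitrogen on an aromatic ring, does not move the number beyond the scatter. Exchanging the 6-(2-hydroxyethoxy)pyridin-3-yl group for 4-(2-hydroxyethoxy)-3-methoxyphenyl comes with a 1.9-fold lower number from compound 2 to compound 3 (0.28 log units; within the scatter), which leaves compound 3 inseparable from compound 2 as well as from compound 1, even though the earlier step of a 2.6-fold higher number from compound 1 to compound 2 (0.42 log units; beyond the scatter) lies beyond the scatter. Nothing available accounts for any of these steps.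

The three compounds leave open whether methoxy would behave in the same way on the 6-(2-hydroxyethoxy)pyridin-3-yl group, a comparison that would separate the effect of the added group from that of the ring atom. They also leave open how far the number depends on the 2-hydroxyethoxy chain itself, which a longer chain such as 3-hydroxypropoxy, or a dimethylamino group in place of the hydroxy, would begin to show.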